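Extending the Fluorinated Chain of Compound 2

The source may report more compounds than this note shows. Statements on the series, on what has been measured and on what is new or still open speak of the compounds shown alone.

Of the compounds shown here, two have so far been tested for growth inhibition. Going by the values given here, in a functional assay on A549 cells (Homo sapiens) for inhibition, read by sulforhodamine B assay, with a stated time of 48 h (a higher number here means a weaker inhibitor of growth, a lower number a stronger inhibitor of growth), compound 2 `O=C(CCC(F)(F)C(F)(F)C(F)(F)C(F)(F)C(F)(F)C(F)(F)F)NCCCCCCCCCN[C@@H]1[C@H](O)[C@@H](O)[C@@H](O)[C@H]2COC(=O)N21` gives 17000 nM, the only true number available so far.

Compound 1 `O=C(CCC(F)(F)C(F)(F)C(F)(F)C(F)(F)C(F)(F)C(F)(F)C(F)(F)C(F)(F)F)NCCCCCCCCCN[C@@H]1[C@H](O)[C@@H](O)[C@H](O)[C@H]2COC(=O)N21` reads > 100000 nM in this assay, and this value is a limit of the assay rather than a number.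

Compound 3 `O=C(CCC(F)(F)C(F)(F)C(F)(F)C(F)(F)C(F)(F)C(F)(F)C(F)(F)C(F)(F)F)NCCCCCCCCCN[C@@H]1[C@H](O)[C@@H](O)[C@@H](O)[C@H]2COC(=O)N21` has not yet been measured. Relative to compound 2, it carries 1,1,2,2,2-pentafluoroethyl in place of fluoro on a saturated chain carbon bound to two fluorine atoms and a saturated chain carbon.

Among the compounds with values here, no measured step isolates this change, so the data give no direct size for it. In this assay the expectation is therefore for no shift beyond the scatter, with any departure more likely toward weaker growth inhibition than toward stronger. The expected step is a 1.3-fold higher number from compound 2 to compound 3 (0.11 log units; within the scatter). Compound 3 could also reach the assay limit rather than give a number. For compound 3 the estimated value is 22000 nM, with an expected range of 8000 nM to 80000 nM.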

Compound 3, concentration for 50% growth inhibition: > 100000 nM
Compound 3: a limit, no number; the forecaster's own chance of this, stated with the estimate: 25%; middle value at least 4.5-fold (0.65 log units) away from the limit.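

In this assay, going by these compounds alone, putting 1,1,2,2,2-pentafluoroethyl in place of fluoro on a saturated chain carbon bound to two fluorine atoms and a saturated chain carbon gives an at least 5.8-fold higher number from compound 2 to compound 3 (0.76 log units; beyond the scatter), the first readable evidence that this change weakens growth inhibition beyond the scatter. The reading for compound 3, > 100000 nM, is a limit of the assay and not a number, so the step gives only a minimum size. The step between compound 1 and compound 3 cannot be read because both compounds sit at the same ceiling: the limit of > 100000 nM in this assay, at which 2 of the 3 values shown sit.

Within the data shown here, what the drawn stereocentre contributes in this assay therefore stays open, and the only comparison bearing on it rests on this pair, with neither member giving a number: the fact that compounds 1 and 3 differ only in the configuration as drawn Also open is whether a plain ethyl group, carrying no fluorine, in place of 1,1,2,2,2-pentafluoroethyl on that same saturated chain carbon would give a number, and how that number would compare with the one for compound 2.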